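Removing the chloro from compound 2: working notes

The source may hold more compounds than are shown below. What is called first, only, known or untested is meant among the compounds shown, and "the series" means these compounds.

Measured so far in a functional assay on A549 cells (Homo sapiens) for inhibition, read by sulforhodamine B assay; a lower number here means a stronger inhibitor, a higher number a weaker inhibitor:
- compound 1 `COC(=O)CC/C(C)=C/Cc1c(OC)c(C)c2c(c1OCC#CCN1CCN(Cc3ccc(Cl)cc3)CC1)C(=O)OC2` gives > 50000 nM as a limit
- compound 2 `COC(=O)CC/C(C)=C/Cc1c(OC)c(C)c2c(c1OCC#CCN1CCN(C(c3ccccc3)c3ccc(Cl)cc3)CC1)C(=O)OC2` gives 29100 nM as a number
- compound 3 `COC(=O)CC/C(C)=C/Cc1c(OC)c(C)c2c(c1OCC#CCN1CCN(c3ccccc3OC)CC1)C(=O)OC2` gives > 50000 nM as a limit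

Going by the values given here, compound 2 with 29100 nM holds the only actual number in the set. The rest of the set is described by the limit of > 50000 nM in this assay, at which 2 of the 3 values shown sit, and those two values are limits, not numbers.

Compound 4 `COC(=O)CC/C(C)=C/Cc1c(OC)c(C)c2c(c1OCC#CCN1CCN(C(c3ccccc3)c3ccccc3)CC1)C(=O)OC2` differs from compound 2 by a single change: hydrogen in place of chloro on an aromatic carbon that is, hydrogen in place of chloro on an aromatic carbon, so 4-chlorophenyl becomes phenyl.

Among the compounds with values here, no measured step covers this change. The nearest is an at least 1.7-fold lower number from compound 1 to compound 2 (0.23 log units; that floor lies within the scatter) and it concerns an added phenyl, not the chloro. The other is a step that the two limits leave unreadable from compound 1 to compound 3 and it offers no size to carry over. With no size and no direction to draw on, no step beyond the scatter is expected in this assay for this change. The expected step is a 1.0-fold higher number from compound 2 to compound 4 (0.01 log units; within the scatter) and this is an estimate only. Compound 4 is estimated at 30000 nM with an expected range from 14000 nM to 50000 nM in the same read-out.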

Compound 4, half-maximal inhibitory concentration: 32700 nM
The estimate for compound 4 lay 1.1-fold (0.04 log units) below the measured number, and the stated range covers the measured number.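

In this assay, going by these compounds alone, hydrogen in place of chloro on the aromatic carbon gives the one step in the set with a number at both ends (a 1.1-fold higher number from compound 2 to compound 4 (0.05 log units; within the scatter)). The earlier steps shown here offered no readable size for this position, whereas this one shows that 4-chlorophenyl and phenyl cannot be told apart in this read-out when the second phenyl stays on the same saturated carbon. The chloro is therefore not required for a number rather than a limit in this pair, since compound 4 gives 32700 nM as a number, though this holds only for compound 2 and compound 4 and says nothing about a ring carrying the chloro on its own, as in compound 1.

The compounds shown leave open whether a different group at this ring carbon, such as a carboxylic acid or an amine, would give a step beyond the scatter, since chloro and hydrogen are the only two substituents compared here. Steps to the remaining compounds also stay without a size, as most of the set's other values are not numbers: the limit of > 50000 nM in this assay, at which 2 of the 4 values shown sit.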